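Methoxy on the second ring system of compound 2

This account rests on a few compounds, and the source may have more. Where it says the series, first, only, none or still open, it means among the compounds named here.

Of the compounds shown here, three have been measured in a functional assay on cells (Cancer cell lines, Homo sapiens) for cytotoxicity, with a stated time of 48 h; on this read-out higher numbers stand for weaker inhibition of growth and lower numbers for stronger inhibition of growth. Compound 1 `COc1cc2c(/C=C3/C(=O)Nc4cccc(Cl)c43)c(Cl)n(Cc3cc(OC)c(OC)c(OC)c3)c2cc1C` gives 22900 nM. Compound 3 `COc1cc2c(c(OC)c1OC)/C(=C\c1c(Cl)[nH]c3ccccc13)C(=O)N2` gives 9770 nM. Compound 2 `COc1c(/C=C2/C(=O)Nc3ccccc32)c2ccccc2n1-c1ccccc1` gives 4070 nM, which is the lowest of the three numbers; its gap to compound 3 and its gap to compound 1 both lie beyond the usual scatter, so compound 2 stands as the strongest inhibitor of growth among the measured set. These three compounds differ from one another in more than one place, so no single change can be read out of any pair of them.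

Compound 4 `COc1ccc2c(c1)/C(=C\c1c(OC)n(-c3ccccc3)c3ccccc13)C(=O)N2` is the next compound and has not yet been measured in this assay. It is built from compound 2 by one change: methoxy in place of hydrogen on an aromatic carbon. The methoxy enters on the six-membered aromatic ring of carbon only that belongs to a fused system of two rings, meta to a fused ring and para to a fused ring.

Within the data shown here, no measured pair in this set isolates such a change, so there is nothing here to say in which direction, if any, it moves the number. Compound 4 is therefore expected to give a value close to that of compound 2, with the step from compound 2 to compound 4 estimated at a 1.1-fold higher number from compound 2 to compound 4 (0.04 log units; within the scatter), a size that stays within the scatter. The estimate for compound 4 is 4500 nM, with a range from 1500 nM to 14000 nM.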

Compound 4, concentration for total growth inhibition: 17400 nM
Beside the measured number, compound 4's estimate is 3.9-fold (0.59 log units) below it, and the stated range ends below it.
By their numbers in this assay, from the lowest: compound 2; then compounds 3, 4 and 1 (each within the scatter of the next, the first and the last beyond it).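

In this assay the replacement of hydrogen by methoxy on the six-membered aromatic ring of carbon only is not a silent change: the step is a 4.3-fold higher number from compound 2 to compound 4 (0.63 log units; beyond the scatter) and lies beyond the scatter, so this position responds, and the added methoxy goes with weaker inhibition of growth. The earlier compounds shown here could not show this, since they differ from one another in more than one place, whereas this pair gives the series its first reading of a single change. No measurement shown bears on what lies behind this step, so the number stands here without an explanation.

The compounds shown leave open whether the loss belongs to methoxy in particular or would follow any group entering on this aromatic carbon, a question that a hydroxyl, a fluorine or an amine in the same place would help to settle. They also leave open whether the step holds on other members of the series, as one pair on the scaffold of compound 2 gives no pattern beyond these two compounds.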